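Fluoro in place of hydroxy on compound 2

This account rests on a few compounds, and the source may have more. Where it says the series, first, only, none or still open, it means among the compounds named here.

Measured in a functional assay on SGC-7901 cells (Homo sapiens) for antiproliferative activity, read by MTT assay, with a stated time of 72 h; a lower number here means a stronger inhibitor, a higher number a weaker inhibitor:
Compound 1 `COc1cc(-n2cnc3ccc(-c4ccc(C)cc4F)cc32)cc(OC)c1OC`: 5650 nM
Compound 2 `COc1ccc(-c2ccc3ncn(-c4cc(OC)c(OC)c(OC)c4)c3c2)cc1O`: 44 nM

Compound 2 holds the lower of the two numbers. Compound 3 `COc1ccc(-c2ccc3ncn(-c4cc(OC)c(OC)c(OC)c4)c3c2)cc1F` differs from it as follows: fluoro in place of hydroxy on an aromatic carbon. The 3-hydroxy-4-methoxyphenyl group becomes 3-fluoro-4-methoxyphenyl, with the change ortho to a methoxy group. Among the measured compounds shown here, only one measured step bears on this, a 130-fold lower number from compound 1 to compound 2 (2.11 log units; beyond the scatter), which is large and beyond the scatter. There, 3-hydroxy-4-methoxyphenyl replaced 2-fluoro-4-methylphenyl, so the hydroxy was not varied alone and that step can only serve as a loose upper guide. Compound 3 keeps the methoxy group but loses the hydroxy, so a moderate move to a higher number in this assay is expected, well short of that step. The estimated move is a 5.0-fold higher number from compound 2 to compound 3 (0.70 log units; beyond the scatter). For compound 3 the expected value is 220 nM, with an estimated range of 50 nM to 1100 nM.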

Compound 3, half-maximal inhibitory concentration: 430 nM
Compound 3: middle estimate off by 2.0-fold (0.29 log units), on the low side; low and high end bracket the measured number.
By their numbers in this assay, from the lowest: compound 2; then compound 3; then compound 1.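

In this assay, the hydroxy on the 3-hydroxy-4-methoxyphenyl group is now changed alone, and fluoro in its place gives a 9.8-fold higher number from compound 2 to compound 3 (0.99 log units; beyond the scatter) as a separate reading, so this one group accounts for a real part of the earlier gain. The 3-fluoro-4-methoxyphenyl group still gives a 13-fold lower number from compound 1 to compound 3 (1.12 log units; beyond the scatter) against 2-fluoro-4-methylphenyl, so a substantial part of that gain survives without the hydroxy. No measurement at hand explains why hydroxy and fluoro differ at this place.

Open, as far as these compounds go, is whether an amine or a carboxylic acid on this aromatic carbon would stay close to the hydroxy or fall back towards the fluoro. Also open, from the compounds shown here alone, is whether the hydroxy keeps its value with an ethoxy group in place of the neighbouring methoxy group.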